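Methoxy for chloro on a chalcone amide: expected effect

The compounds below may be only part of what the source reports. "The series", "measured", "known", "first", "only" and "open" are said of these compounds alone.

Measured compounds:
Compound 1 `CC(O[N+](=O)[O-])C(=O)Nc1ccc(C(=O)/C=C/c2ccc(Cl)cc2)cc1`: 56%
Compound 2 `COc1ccc(/C=C/C(=O)c2ccc(NC(=O)C(C)O[N+](=O)[O-])cc2)cc1`: 35%
Compound 3 `O=C(COCc1c(-c2ccccc2)no[n+]1[O-])Nc1ccc(C(=O)/C=C/c2ccc(Cl)cc2)cc1`: 62%

All three were tested in a functional assay on the whole organism (strain albino) for inhibition, with Rattus norvegicus as the target, read by paw edema, with stated times of 30 min and 5 h, at a dose of 100 mg/kg by the oral route; a lower number here means less inhibition, a higher number more inhibition at the dose given (going by the name of the read-out). Compound 3 has the highest number of the three, but compound 1 lies within the scatter of it, so the two cannot be ordered; compound 2 sits well below both.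

Compound 1 and compound 2 differ in one place: methoxy in place of chloro on an aromatic carbon. That change gave a number 21 percentage points lower from compound 1 to compound 2 (beyond the scatter).

Compound 3 and compound 1 carry different amide side chains; the difference between the two cores is not broken down here.

Compound 4 `COc1ccc(/C=C/C(=O)c2ccc(NC(=O)COCc3c(-c4ccccc4)no[n+]3[O-])cc2)cc1` has not yet been measured. It differs from compound 3 exactly as compound 2 differs from compound 1: methoxy in place of chloro on an aromatic carbon. Among the measured compounds shown here, since the change and its place are the same, the step from compound 3 to compound 4 is expected to resemble the one from compound 1 to compound 2, because compound 3 starts from 62% and the earlier step was a number 21 percentage points lower from compound 1 to compound 2 (beyond the scatter). The expected step is a number 21 percentage points lower from compound 3 to compound 4 (beyond the scatter). On this basis compound 4 is estimated at 41%, likely between 28% and 54%.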

Compound 4, a percentage reported as inhibition, in the whole organism at one dose (the size of the read-out at that dose, not a potency): 49%
Compound 4: the middle estimate sits 8 percentage points below what was measured; low and high end bracket the measured number.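

In this assay, putting methoxy in place of chloro gave a number 13 percentage points lower from compound 3 to compound 4 (beyond the scatter), so the change pointed the same way on the second amide side chain as on the first. The two steps can be treated as one effect of similar size, since the gap between them is no larger than repeat measurements would produce: the same change on two cores in this assay, a number 21 percentage points lower (beyond the scatter) from compound 1 to compound 2 and a number 13 percentage points lower (beyond the scatter) from compound 3 to compound 4, 8 percentage points apart, within the scatter of two such steps

This shows that, within these two pairs, the drop carried over from one core to the other, but two pairs are a small sample from a single read-out at a single dose, so it does not show that the change would behave the same way on other cores, nor why the number falls.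

The compounds shown leave open whether the drop comes from losing chloro or from gaining methoxy. A fluoro, a plain hydrogen or an amine at that same place on the ring could separate the two, and a longer chain in the amide side chain would test the change on a further core.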